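The compounds below may be only part of what the source reports. "The series", "measured", "known", "first", "only" and "open" are said of these compounds alone.

Working notes on the series. Compound 1 `O=C(Nc1ccc(Cl)cc1)c1cc([N+](=O)[O-])ccc1Cl`, compound 2 `O=C(Nc1cccc(-c2nc3ccccc3s2)c1)c1cnccc1Cl` and compound 3 `Cc1ccc(-c2nc3ccccc3s2)cc1NC(=O)c1cnccc1Cl` are the measured members. In an ADME assay on BJ cells (Homo sapiens) for inhibition, with a stated time of 72 h (a lower number here means that less compound is needed, a higher number that more compound is needed for the effect), compound 1 gives > 25000 nM, which is a limit of the assay and not a number. In this assay compound 2 gives > 25000 nM, likewise a limit. In this assay compound 3 gives > 25000 nM, again a limit. Compound 3 therefore stands where the whole measured set stands: the limit of > 25000 nM in this assay, at which 3 of the 3 values shown sit. The only single-point step among these compounds, a step that the two limits leave unreadable from compound 2 to compound 3, is left unreadable by the two limits, so its size is unknown.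

Compound 4 `COc1ccc(-c2nc3ccccc3s2)cc1NC(=O)c1cnccc1Cl` carries one change relative to compound 3: methoxy in place of methyl on an aromatic carbon. For the measured compounds named here, no measured step bears on this change with a readable size; the single related step is the unreadable one just named. With every shown value sitting at the limit, the expected step of a number no higher from compound 3 to compound 4 (the limit leaves the size open) is none beyond the scatter. Compound 4 is therefore expected to give about 25000 nM in this assay, within an estimated range of 8000 nM to 100000 nM, most probably reported again as a limit rather than a number.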

Compound 4, half-maximal effective concentration: > 25000 nM
Compound 4 ended at the assay's limit (the forecaster's own chance of this, stated with the estimate: 85%); the middle value sits exactly at the limit.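

The steps among compound 2, compound 3 and compound 4 cannot be read, as all three sit at the same limit in this assay: the limit of > 25000 nM in this assay, at which 4 of the 4 values shown sit.

The compounds shown leave open what size, if any, the methyl and methoxy changes have, and at what concentration any compound reaches the half-maximal effect.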